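Moving the Trifluoromethyl Around the Anilino Ring

The source may report more compounds than this note shows. Statements on the series, on what has been measured and on what is new or still open speak of the compounds shown alone.

Compound 1 `CCCCCCCCCCCCCCNc1nc(SCc2ccc(C(F)(F)F)cc2)nc2ccccc12`: > 50000 nM
Compound 2 `FC(F)(F)c1ccc(CSc2nc(Nc3ccccc3C(F)(F)F)c3ccccc3n2)cc1`: > 50000 nM

Both values are limits of a functional assay on MDA-MB-231 cells (Homo sapiens) for cytotoxicity, read by MTT assay, with a stated time of 72 h (a lower number here means a stronger inhibitor, a higher number a weaker inhibitor), rather than measured numbers. Compound 2 stands at the limit > 50000 nM. Compound 1 sits at that same limit, > 50000 nM.

Compound 3 `FC(F)(F)c1ccc(CSc2nc(Nc3cccc(C(F)(F)F)c3)c3ccccc3n2)cc1` differs from compound 2 by 3-(trifluoromethyl)phenyl in place of 2-(trifluoromethyl)phenyl on a nitrogen on an aromatic ring. Among the compounds with values here, no two measured compounds differ in just one place, so there is no measured step to lean on; the only guide is the limit of > 50000 nM in this assay, at which 2 of the 2 values shown sit. The change expected in this assay, a step that the limit leaves unreadable from compound 2 to compound 3, is none beyond the scatter. Compound 3 is expected to give 60000 nM, within 20000 nM to 200000 nM, and will most likely again show only a limit.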

Compound 3, half-maximal inhibitory concentration: 11100 nM
Estimate against measurement, compound 3: 5.4-fold (0.73 log units) above; measured number below the stated range.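

Replacing 2-(trifluoromethyl)phenyl with 3-(trifluoromethyl)phenyl on the nitrogen gives an at least 4.5-fold lower number from compound 2 to compound 3 (0.65 log units; beyond the scatter) in this assay. The two compounds hold the same atoms, joined differently, so at this nitrogen the arrangement of the ring substituent alone changes the read-out. Compound 3 is the only compound shown with a measured number rather than a limit: the limit of > 50000 nM in this assay, at which 2 of the 3 values shown sit.

The compounds shown do not tell whether a nitrile or a methoxy group in place of the trifluoromethyl would give a similar number. They also give no reason for the change.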